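The compounds below may be only part of what the source reports. "The series", "measured", "known", "first", "only" and "open" are said of these compounds alone.

For the measured compounds named here, in a functional assay on DU-145 cells (Homo sapiens) for cytotoxicity, read by MTT assay, with a stated time of 48 h (a higher number here means a weaker inhibitor, a lower number a stronger inhibitor), compound 2 (`COc1cc(/C=C/c2ccccc2)c(-c2ccccc2)c(OC)c1OC`) gives 82000 nM, the highest of the two numbers so far. Compound 1 (`COc1ccc(/C=C/c2cc(OC)c(OC)c(OC)c2-c2ccc(F)c(F)c2)cc1`) gives 7500 nM, a lower number by a margin beyond the scatter. Compound 3 (`C=C(c1ccc(Cl)cc1)c1cc(OC)c(OC)c(OC)c1-c1ccccc1`) is still unmeasured and has 1-(4-chlorophenyl)ethenyl in place of the 2-phenylethenyl of compound 2, on an aromatic carbon ortho to a phenyl group: 1-(4-chlorophenyl)ethenyl in place of 2-phenylethenyl on an aromatic carbon. Going by the values given here, no measured step between compounds differing in one place is available, so the expectation rests on these two values alone. Compound 2 at 82000 nM sits at the top of the range and compound 1 at 7500 nM shows that lower numbers occur, so a moderate move toward a lower number in this assay is expected. The estimated step is a 3.7-fold lower number from compound 2 to compound 3 (0.57 log units; beyond the scatter). For compound 3 the expected value is 22000 nM, with an estimated range of 6000 nM to 80000 nM.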

Compound 3, half-maximal inhibitory concentration: 29000 nM
Compound 3: the middle estimate sits 1.3-fold (0.12 log units) below what was measured, and the stated range covers the measured number.
By their numbers in this assay, from the lowest: compound 1; then compound 3; then compound 2.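

In this assay, for the compounds shown here, 1-(4-chlorophenyl)ethenyl in place of 2-phenylethenyl, on the aromatic carbon ortho to a phenyl group, gives a 2.8-fold lower number from compound 2 to compound 3 (0.45 log units; beyond the scatter) and is the first single-place step. The position therefore accepts this swap with a modest move toward a lower number, not a loss, though the step is a single one and sets no trend. The swap changes two things at once, where the aromatic ring sits on the double bond and the added chlorine, and no data here bear on why the number falls.

On these data alone, how the step divides between those two changes stays open, and a plain 1-phenylethenyl group would address that. Also open, as far as these compounds go, is how this position responds to an amine or a carboxylic acid in place of the chlorine.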